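This account rests on a few compounds, and the source may have more. Where it says the series, first, only, none or still open, it means among the compounds named here.

Two compounds of the series have numbers in an assay for inhibition of lanosterol synthase (Rattus norvegicus), using microsomes (on this read-out higher numbers stand for weaker inhibition and lower numbers for stronger inhibition), so far. Compound 1 `O=C(c1ccc(C(F)(F)F)cc1)N1CCC(=Cc2ccc(C3=NCCO3)cc2)CC1` gives 90 nM in this assay. Compound 2 `O=C(C1CCN(c2ccncc2)CC1)N1CCN(S(=O)(=O)c2ccccc2)CC1` gives 326 nM in this assay, the higher of the two numbers, and the gap to compound 1 is beyond the usual scatter.

Compound 3 `O=C(C1CCN(c2ccncc2)CC1)N1CCN(S(=O)(=O)c2ccc(Br)cc2)CC1` has not been measured. It differs from compound 2 in one place: bromo in place of hydrogen on an aromatic carbon. Among the measured compounds shown here, no pair of measured compounds shows this change, so the size and direction of its step in this assay cannot be read from the data at hand. The expectation is a step of roughly a 1.4-fold lower number from compound 2 to compound 3 (0.15 log units; within the scatter), which is not clearly beyond the scatter in either direction. On that basis compound 3 is estimated at 230 nM in this assay, with a range from 70 nM to 750 nM.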

Compound 3, half-maximal inhibitory concentration: 228 nM
Estimate against measurement, compound 3: 1.0-fold (0.00 log units) above; measured number inside the range.
By their numbers in this assay, from the lowest: compound 1; then compounds 3 and 2 (each within the scatter of the next).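

In this assay, the change from phenyl to 4-bromophenyl on the sulfonyl group gives a 1.4-fold lower number from compound 2 to compound 3 (0.16 log units; within the scatter), the first single-place step available in the series. At this aromatic carbon, one bromine atom in place of hydrogen therefore does not separate compound 3 from compound 2 on this read-out. No measurement at hand bears on the reason for the size of this step.

From the compounds shown here alone, whether an amine or a carboxylic acid on the same aromatic carbon would give a step beyond the scatter stays open, as does the outcome of bromo on other carbons of that ring. Compound 1 differs from this pair in more than one place, so it offers no reading of this change.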